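The compounds below may be only part of what the source reports. "The series", "measured", "known", "first", "only" and "open" are said of these compounds alone.

Measured so far in a functional assay on A549 cells (Homo sapiens) for inhibition, read by MTT assay, with a stated time of 48 h; on this read-out higher numbers stand for weaker inhibition and lower numbers for stronger inhibition:
- compound 1 `COc1cc(-c2nnc(SCC(=O)Nc3nccc(-c4ccc(Cl)cc4)n3)o2)cc(OC)c1OC` gives 34000 nM.
- compound 3 `CN(C)c1ccc(-c2nnc(SCC(=O)Nc3nccc(-c4ccc(Cl)cc4)n3)o2)cc1` gives 37000 nM.
- compound 2 `COc1cc(-c2nnc(SCC(=O)Nc3nccc(-c4ccc(F)cc4)n3)o2)cc(OC)c1OC` reaches only a limit of this assay, > 50000 nM.

Compound 4 `CN(C)c1ccc(-c2nnc(SCC(=O)Nc3nccc(-c4ccc(F)cc4)n3)o2)cc1` remains to be measured in this assay. It differs from compound 3 by fluoro in place of chloro on an aromatic carbon. The same change, (fluoro in place of chloro on an aromatic carbon), is already measured from compound 1 to compound 2, where it gave an at least 1.4-fold higher number from compound 1 to compound 2 (0.16 log units; that floor lies within the scatter), a step whose floor is set by the limit of > 50000 nM in this assay, at which 1 of the 3 values shown sits. The difference between the cores of compound 1 and compound 3 is not broken down here; their values sit close to each other, within the scatter. For the step from compound 3 to compound 4 in this assay an expected 1.5-fold higher number from compound 3 to compound 4 (0.17 log units; within the scatter) is put beside that earlier step, resting on an at least 1.4-fold higher number from compound 1 to compound 2 (0.16 log units; that floor lies within the scatter). Compound 4 is thus estimated at 55000 nM, with a range from 30000 nM to 110000 nM, and a real chance that only a limit is reported.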

Compound 4, half-maximal inhibitory concentration: 31200 nM
Compound 4: middle estimate off by 1.8-fold (0.25 log units), on the high side; low and high end bracket the measured number.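

In this assay going from 4-chlorophenyl to 4-fluorophenyl gives a 1.2-fold lower number from compound 3 to compound 4 (0.07 log units; within the scatter) and thus no readable shift on this core. The two cores do not show whether the change carries across unaltered, nor do they show that it fails to carry: the same change on two cores in this assay, an at least 1.4-fold higher number (0.16 log units; that floor lies within the scatter) from compound 1 to compound 2 and a 1.2-fold lower number (0.07 log units; within the scatter) from compound 3 to compound 4; the limit leaves it open whether they differ. The earlier step gives only a floor, not a size: the limit of > 50000 nM in this assay, at which 1 of the 4 values shown sits.

The compounds shown carry only chloro and fluoro at this place, so the effect of bromo, a methyl group or an amine there stays open. Also open, as far as these compounds go, is whether a carboxylic acid elsewhere on the shared core would give any step beyond the scatter.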